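Core change and side-chain trimming in the tail flick test

The source may hold more compounds than are shown below. What is called first, only, known or untested is meant among the compounds shown, and "the series" means these compounds.

Compound 1 `NC(=O)CC[C@H](NC(=O)CN(c1ncnc2c1ncn2C1CCCCO1)C1CC1)C(=O)OCc1ccccc1`: 10.7%
Compound 2 `C[C@H](NC(=O)CN(c1ncnc2c1ncn2C1CCCCO1)C1CC1)C(=O)OCc1ccccc1`: 6.01%
Compound 3 `NC(=O)CC[C@H](NC(=O)CN(c1nc(Cl)nc2[nH]cnc12)C1CC1)C(=O)O`: 11.4%

Of the compounds shown here, three have been measured in a functional assay on the whole organism (Tail, strain ICR) with Mus musculus as the target, in the tail flick test, with a stated time of 150 min, at a dose of 25 umol/kg by the oral route; on this read-out lower numbers stand for a weaker effect and higher numbers for a stronger effect at the one dose given. Compound 1 and compound 2 share one core and differ by a single change, (hydrogen in place of carbamoylmethyl on a saturated chain carbon, two bonds along the chain from an amide-type nitrogen and a carbonyl carbon). That step, a number 4.7 percentage points lower from compound 1 to compound 2 (within the scatter), lies within the scatter, so the two values cannot be told apart. Compound 3 has a different core; how its core differs from that of compound 1 is not broken down here. In this assay compound 3 gives 11.4%, a value within the scatter of compound 1 and of compound 2.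

Compound 4 `C[C@H](NC(=O)CN(c1nc(Cl)nc2[nH]cnc12)C1CC1)C(=O)O` has not yet been measured. It stands to compound 3 as compound 2 stands to compound 1: the change is hydrogen in place of carbamoylmethyl on a saturated chain carbon, two bonds along the chain from an amide-type nitrogen and a carbonyl carbon, the same change, at the same place, seen in the pair compound 1 to compound 2. Because a number 4.7 percentage points lower from compound 1 to compound 2 (within the scatter) stayed within the scatter, the same kind of step is expected from compound 3 to compound 4, an estimated a number 3.9 percentage points lower from compound 3 to compound 4 (within the scatter). Compound 4 is therefore expected to give 7.5% in this assay, most likely between 0% and 18%.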

Compound 4, a percentage reported as activity, at one dose (the size of the read-out at that dose, not a potency): 14.7%
Compound 4: the middle estimate sits 7.2 percentage points below what was measured; measured number inside the range.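

On the core of compound 3, hydrogen in place of carbamoylmethyl gives, in this assay, a number 3.3 percentage points higher from compound 3 to compound 4 (within the scatter). Set beside the step on the core of compound 1, the change cannot be told apart on the two cores: the same change on two cores in this assay, a number 4.7 percentage points lower (within the scatter) from compound 1 to compound 2 and a number 3.3 percentage points higher (within the scatter) from compound 3 to compound 4, 8 percentage points apart, within the scatter of two such steps The pair of steps therefore gives no sign that the core alters what this change does, but with both steps inside the scatter it does not show that the change has any effect on either core, and so it cannot show that an effect carries from one core to the other.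

The compounds shown leave open how a longer chain, an amine or a carboxylic acid would read in place of carbamoylmethyl, on a saturated chain carbon, two bonds along the chain from an amide-type nitrogen and a carbonyl carbon. They also leave open whether any such group would give a step that stands clear of the scatter on either core.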